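The source may hold more compounds than are shown below. What is called first, only, known or untested is meant among the compounds shown, and "the series" means these compounds.

Compound 1 `COC1=C(C)C(=O)/C(=C(O)/C=C/c2cccc(OC)c2)C(=O)C1(C)C`, compound 2 `COC1=C(C)C(=O)/C(=C(O)/C=C/c2ccccc2OC)C(=O)C1(C)C` and compound 3 `COC1=C(C)C(=O)/C(=C(O)/C=C/c2ccc(F)cc2)C(=O)C1(C)C` share one core and differ only in the substituted phenyl group on a double-bonded chain carbon bound to a double-bonded chain carbon. In a functional assay on A-431 cells (Homo sapiens) for cytotoxicity (on this read-out lower numbers stand for an effect already at smaller amounts and higher numbers for an effect only at larger amounts of compound), compound 1 gives 4.5 ug/mL, compound 2 gives 6.6 ug/mL and compound 3 gives 4.1 ug/mL. Compound 3 therefore cannot be told apart from the other two, since a 1.1-fold lower number from compound 1 to compound 3 (0.04 log units; within the scatter) and a 1.6-fold lower number from compound 2 to compound 3 (0.21 log units; within the scatter) both lie within the scatter of repeated measurements.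

Compound 4 `COC1=C(C)C(=O)/C(=C(O)/C=C/c2ccccc2C)C(=O)C1(C)C` keeps the core but carries 2-methylphenyl in place of 4-fluorophenyl on a double-bonded chain carbon bound to a double-bonded chain carbon. For the measured compounds named here, the steps that bear on this change are the swaps already measured at the same place. Those two, together with a 1.5-fold higher number from compound 1 to compound 2 (0.17 log units; within the scatter), all stayed within the scatter, so three different groups have so far made no measurable difference here. On these data alone, the same may hold for a fourth, although 2-methylphenyl itself is untested. The expected change is a 1.3-fold higher number from compound 3 to compound 4 (0.13 log units; within the scatter), an estimate that stays within the scatter in this assay. For compound 4 the estimated value is 5.5 ug/mL, with an expected range of 3.2 ug/mL to 9.5 ug/mL.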

Compound 4, concentration for half-maximal effect: 5.2 ug/mL
For compound 4 the middle estimate is 1.1-fold (0.02 log units) above the measured one; the range from low to high includes it.
By their numbers in this assay, from the lowest: compounds 3, 1, 4 and 2 (each within the scatter of the next).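

With a 1.3-fold higher number from compound 3 to compound 4 (0.10 log units; within the scatter) and a 1.2-fold higher number from compound 1 to compound 4 (0.06 log units; within the scatter) in this assay 2-methylphenyl joins the three earlier groups as a fourth that cannot be told apart from them at this place. Compound 2 and compound 4 differ more narrowly than any earlier pair, only by methyl in place of methoxy on an aromatic carbon, and a 1.3-fold lower number from compound 2 to compound 4 (0.10 log units; within the scatter) shows that this small swap also makes no measurable difference. Nothing measured here explains why these groups behave alike. On these data alone, all four groups are phenyl rings with one substituent, so it remains open whether this place stays as insensitive to a group of another kind, such as a ring carrying an amine or a carboxylic acid, or a longer chain in place of the ring. As far as these compounds go, it also remains open whether a change elsewhere on the shared core would move the number beyond the scatter.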